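This account rests on a few compounds, and the source may have more. Where it says the series, first, only, none or still open, it means among the compounds named here.

Of the compounds shown here, three have so far been tested in a functional assay on LM7 cells (Homo sapiens) for cytotoxicity, read by MTT assay, with a stated time of 72 h; a higher number here means a weaker inhibitor, a lower number a stronger inhibitor. Compound 1 `Cc1nnc(SCc2cc(=O)c3ccccc3o2)o1` reaches only a limit of the assay, > 25000 nM. Compound 3 `O=c1cc(CSc2nc3ccccc3s2)oc2ccccc12` likewise stops at a limit, > 25000 nM. For the measured compounds named here, compound 2 `Cc1nnc(SCc2coc3ccc(Cl)cc3c2=O)o1` is the one compound with a number, 8700 nM, while the other two sit at the limit of > 25000 nM in this assay, at which 2 of the 3 values shown sit. Compound 4 `Cc1nnc(SCc2coc3ccccc3c2=O)o1` remains unmeasured. It differs from compound 2 by hydrogen in place of chloro on an aromatic carbon. Going by the values given here, no measured pair differs in a single place, so the size of this step can only be estimated. Compound 1, which also carries no chloro, stays at a limit, > 25000 nM. With that in view, a loss of potency is expected, a 2.3-fold higher number from compound 2 to compound 4 (0.36 log units; beyond the scatter). Compound 4 is therefore estimated to give 20000 nM, within 7000 nM to 60000 nM.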

Compound 4, half-maximal inhibitory concentration: 3500 nM
Compound 4: the middle estimate sits 5.7-fold (0.76 log units) above what was measured, outside the stated range (below it).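

Replacing chloro with hydrogen on this aromatic carbon gives a 2.5-fold lower number from compound 2 to compound 4 (0.40 log units; beyond the scatter) in this assay, and a lower number here means a stronger inhibitor. The chloro is therefore not needed for a measurable effect in this series, and at this place hydrogen does better than chloro. Nothing shown here gives a reason for this gain.

On these data alone, only hydrogen and chloro can be compared at this place, so it remains open how a fluoro or methoxy group would behave there. This single step also cannot show whether the same change would have a similar effect on the other cores.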